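A few compounds are considered here, and "the series" means these few. Any claim that something is new, unique, unknown or untested is made for them only; others in the source may bear on it.

Of the compounds shown here, two carrying the shared urea-bearing core have been measured in a functional assay on MDA-MB-231 cells (Homo sapiens) for cytotoxicity, read by MTT assay, with a stated time of 72 h; a lower number here means a stronger inhibitor, a higher number a weaker inhibitor. Compound 1 `CN(C)CCCNc1nc(-c2ccc(NC(=O)Nc3ccc(Cl)cc3Cl)cc2)nc2ccsc12`, whose amide-type nitrogen bears a 2,4-dichlorophenyl group and whose side chain is the longer of the two, gives 1860 nM. Compound 2 `CN(C)CCNc1nc(-c2ccc(NC(=O)Nc3ccccc3F)cc2)nc2ccsc12`, with a 2-fluorophenyl group on that nitrogen and the shorter side chain, gives 600 nM in this assay, the lower of the two numbers, and its gap to compound 1 lies beyond the scatter. Compound 3 `CN(C)CCNc1nc(-c2ccc(NC(=O)Nc3ccc(Cl)cc3Cl)cc2)nc2ccsc12` has not yet been measured. It keeps the shorter side chain of compound 2 and differs from it in one place: 2,4-dichlorophenyl in place of 2-fluorophenyl on an amide-type nitrogen. For the measured compounds named here, no pair of measured compounds shows this change on its own, so no step for it is known; compound 1 also carries the 2,4-dichlorophenyl group but differs further in its chain, and its number is the higher one. Compound 3 is therefore expected to give about 1000 nM in this assay, in a range from 400 nM to 2500 nM. The expected step of a 1.7-fold higher number from compound 2 to compound 3 (0.22 log units; within the scatter) is a weakening that may or may not exceed the scatter.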

Compound 3, half-maximal inhibitory concentration: 2450 nM
Beside the measured number, compound 3's estimate is 2.5-fold (0.39 log units) below it, within the range that was stated.
By their numbers in this assay, from the lowest: compound 2; then compounds 1 and 3 (each within the scatter of the next).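

In this assay, the exchange of 2-fluorophenyl for 2,4-dichlorophenyl on the amide-type nitrogen now has a measured step of its own (a 4.1-fold higher number from compound 2 to compound 3 (0.61 log units; beyond the scatter)), a modest weakening that stands clear of the scatter, with the shorter side chain held constant. For the compounds shown here, the new compound also gives the first direct look at the side chain with the 2,4-dichlorophenyl group held fixed: dimethylamino in place of (dimethylamino)methyl on the saturated chain carbon gives a step within the scatter (a 1.3-fold higher number from compound 1 to compound 3 (0.12 log units; within the scatter)), so in this pair the length of the chain does not separate the two numbers. Nothing available here accounts for either step.

From the compounds shown here alone, both readings rest on one pair each, so it remains open whether the side chain would count for as little with the 2-fluorophenyl group in place, or whether the step on the nitrogen would be the same with the longer chain. Going by these compounds, it is also open how a plain phenyl, a 2-chlorophenyl or a 4-chlorophenyl group on that nitrogen would stand, and so whether one chlorine alone would carry the step.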